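The source may report more compounds than this note shows. Statements on the series, on what has been measured and on what is new or still open speak of the compounds shown alone.

Working notes on the series. Three compounds carry the shared core with a piperidine-bearing pyrazole and a substituted aryl group on the five-membered aromatic ring with one nitrogen and one oxygen. Compound 1 `Cc1c(-c2cc(-c3ccccc3Cl)no2)cnn1C1CCNCC1` gives 71% in an assay on a protein complex for positive allosteric modulation of Neuronal acetylcholine receptor; alpha4/beta2 (Homo sapiens); on this read-out lower numbers stand for smaller maximal responses and higher numbers for larger maximal responses. Compound 3 `Cc1c(-c2cc(-c3c(F)cccc3Cl)no2)cnn1C1CCNCC1` gives 66% in this assay, and a number 5 percentage points lower from compound 1 to compound 3 (within the scatter). Compound 2 `Fc1cccc(Cl)c1-c1cc(-c2cnn(C3CCNCC3)c2)on1` gives 60% in this assay, the lowest of the three numbers; the nearest is compound 3, since a number 6 percentage points higher from compound 2 to compound 3 (within the scatter), while the gap to compound 1 lies beyond the scatter.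

Compound 4 `Clc1sccc1-c1cc(-c2cnn(C3CCNCC3)c2)on1` has not yet been measured. It differs from compound 2 by 2-chlorothiophen-3-yl in place of 2-chloro-6-fluorophenyl on an aromatic carbon. Neither measured step covers an exchange of the whole aryl group: the step from compound 1 to compound 3 only adds fluoro on that ring and stays within the scatter, and the step from compound 2 to compound 3 touches a different ring. Among the compounds with values here, the only guidance is that the three measured numbers sit in a narrow band, so the expectation is for no step beyond the scatter in this assay, with wide uncertainty. Compound 4 is therefore estimated at 62% in this assay, within 45% to 80%. This estimate means a step of a number 2 percentage points higher from compound 2 to compound 4 (within the scatter), expected to stay within the scatter.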

Compound 4, largest response reached (reported as efficacy), in percent of the reference or control that the assay uses: 42%
Compound 4: the middle estimate sits 20 percentage points above what was measured, outside the stated range (below it).
By their numbers in this assay, from the lowest: compound 4; then compounds 2, 3 and 1 (each within the scatter of the next, the first and the last beyond it).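

In this assay, putting 2-chlorothiophen-3-yl in place of 2-chloro-6-fluorophenyl on the aromatic carbon next to the ring nitrogen gives a number 18 percentage points lower from compound 2 to compound 4 (beyond the scatter), so this position responds to an exchange of the whole aryl group in a way that the added fluoro of a number 5 percentage points lower from compound 1 to compound 3 (within the scatter) did not show. The change replaces a six-membered aromatic ring of carbon only with a five-membered aromatic ring with a sulfur atom while the chlorine stays, and it removes the fluorine as well, so this single step cannot separate the contribution of the ring from that of the fluorine. Nothing measured alongside these numbers accounts for the step, and its cause remains unassigned.

On these data alone, it remains open whether the lower response follows the thiophene ring itself or the loss of the fluorine, and whether the methyl group on the pyrazole would alter the outcome with 2-chlorothiophen-3-yl in place. Other groups at this position, such as 2-methylthiophen-3-yl or 2-chloropyridin-3-yl, would test how far the response depends on the ring and on the chlorine.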